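The source may report more compounds than this note shows. Statements on the series, on what has been measured and on what is new or still open speak of the compounds shown alone.

In a physicochemical assay for acid dissociation, compound 1 `CN(Cc1ccc(Cl)cc1)Cc1ccccc1CNc1ccnc2cc(Cl)ccc12` gives 9.6, compound 2 `CN(Cc1ccc(Cl)cc1)Cc1ccc(CNc2ccnc3cc(Cl)ccc23)cc1` gives 9.74 and compound 3 `CN(Cc1ccc(Cl)cc1)Cc1cccc(CNc2ccnc3cc(Cl)ccc23)c1` gives 9.89. These three compounds carry the same groups, arranged differently. Their values all lie within the usual scatter of one another, so compound 2 stands level with both of the others and no ranking can be read from them.

Compound 4 `CN(Cc1ccc(CNc2ccnc3cc(Cl)ccc23)cc1)Cc1ccc(N(C)C)cc1` differs from compound 2 in one place. It has dimethylamino in place of chloro on an aromatic carbon, para to a large group, so that 4-chlorobenzyl becomes 4-(dimethylamino)benzyl (dimethylamino in place of chloro on an aromatic carbon).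

Among the measured compounds shown here, no pair of measured compounds shows a change at this place, so the data give no direct size for such a step. For the measured compounds named here, the only guide is how closely the three measured values sit together. Starting from compound 2 at 9.74, a small step is expected, with a slight upward lean but nothing beyond the scatter. The estimated change is a number 0.06 log units higher from compound 2 to compound 4 (within the scatter). For compound 4 the estimated value in this assay is 9.8, with an expected range from 9.4 to 10.2.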

Compound 4, acid dissociation constant: 9.66
For compound 4 the middle estimate is 0.14 log units above the measured one; low and high end bracket the measured number.
By their numbers in this assay, from the lowest: compounds 1, 4, 2 and 3 (each within the scatter of the next).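

Replacing chloro with dimethylamino on the aromatic carbon, para to a large group, turns 4-chlorobenzyl into 4-(dimethylamino)benzyl, and the result in this assay is a number 0.08 log units lower from compound 2 to compound 4 (within the scatter) for this swap. Among the compounds shown here, this is the one direct reading at this position, and it places compound 2 and compound 4 level with each other, even though one chlorine atom gives way to a group of three heavy atoms that counts one hydrogen-bond acceptor. No supporting measurement bears on this result, so it stands as an observation without an explanation.

One step at a single position cannot show whether other groups in place of chloro, such as a carboxylic acid, a primary amine or a longer alkyl chain, would also leave the value level with that of compound 2. It also leaves open whether the same swap from chloro to dimethylamino would read the same way on compound 1 or compound 3, where the shared groups are arranged differently around the central benzene ring.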